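Working notes: from compound 2 to compound 4

The compounds below may be only part of what the source reports. "The series", "measured", "known", "first", "only" and "open" are said of these compounds alone.

Measured so far in a functional assay on 4T1 cells (Mus musculus) for cytotoxicity, read by MTT assay, with a stated time of 24 h; a higher number here means a weaker inhibitor, a lower number a stronger inhibitor:
- compound 1 `COc1ccc(/C=C2\CN(C(=S)SCc3cn(Cc4ccc(F)cc4)nn3)C/C(=C\c3ccc(OC)cc3)C2=O)cc1`: > 100000 nM (a limit of the assay, not a number)
- compound 2 `Cc1ccc(/C=C2\CN(Cc3cn(Cc4ccc(F)cc4)nn3)C/C(=C\c3ccc(C)cc3)C2=O)cc1`: 57200 nM
- compound 3 `Cc1ccc(/C=C2\CN(C(=S)SCc3cn(Cc4cccc(Cl)c4)nn3)C/C(=C\c3ccc(C)cc3)C2=O)cc1`: 53400 nM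

The entry for compound 1 is a limit. Compound 2 gives 57200 nM and compound 3 gives 53400 nM in this assay, and these two values lie within the scatter of each other.

Compound 4 `Cc1ccc(/C=C2\CN(Cc3cn(Cc4ccccc4Cl)nn3)C/C(=C\c3ccc(C)cc3)C2=O)cc1` has not yet been measured. Its difference from compound 2 is 2-chlorophenyl in place of 4-fluorophenyl on a saturated chain carbon bound to an aromatic nitrogen, with 2-chlorophenyl in place of 4-fluorophenyl on a saturated chain carbon bound to an aromatic nitrogen.

Among the compounds with values here, no measured pair isolates this change, so the expectation rests on the numbers for compound 2 and compound 3 alone. No step beyond the scatter is expected in this assay, in either direction. The estimated change is a 1.3-fold lower number from compound 2 to compound 4 (0.10 log units; within the scatter) and it is expected to stay within the scatter. Compound 4 is expected at 45000 nM in this assay, with an estimated range of 18000 nM to 100000 nM.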

Compound 4, half-maximal inhibitory concentration: 23200 nM
The estimate for compound 4 lay 1.9-fold (0.29 log units) above the measured number; the range from low to high includes it.
By their numbers in this assay, from the lowest: compound 4; then compounds 3 and 2 (each within the scatter of the next). At a limit, above all of these: compound 1.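

In this assay, within the data shown here, 2-chlorobenzyl in place of 4-fluorobenzyl gives a 2.5-fold lower number from compound 2 to compound 4 (0.39 log units; beyond the scatter), the first step that lies beyond the scatter, although it is a modest one. The earlier compounds shown here differ in more than one place and could not show that the group on this saturated chain carbon bound to an aromatic nitrogen affects the read-out. The change replaces both the halogen and its printed ring position, so this single step cannot separate the two.

From the compounds shown here alone, the entry for compound 1 is a limit, and the steps that would involve it cannot be read: the limit of > 100000 nM in this assay, at which 1 of the 4 values shown sits. Still open is how a 2-fluorobenzyl, 4-chlorobenzyl or unsubstituted benzyl group, or a benzyl group carrying an amine, would read at this position.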